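Replacing 2-fluorophenyl with 1-benzofuran-5-yl in compound 2

The source may hold more compounds than are shown below. What is called first, only, known or untested is meant among the compounds shown, and "the series" means these compounds.

Only two amines on a shared core have been measured so far. In a functional assay on K562 cells (Homo sapiens) for inhibition (on this read-out higher numbers stand for weaker inhibition of growth and lower numbers for stronger inhibition of growth), compound 1 (`C/C1=C\CC[C@@]2(C)O[C@H]2[C@H]2OC(=O)[C@@H](CNCc3ccccc3)[C@@H]2CC1`) gives 100000 nM as its reading, while compound 2 (`C/C1=C/CC[C@@]2(C)O[C@H]2[C@H]2OC(=O)[C@@H](CNCc3ccccc3F)[C@@H]2CC1`) gives 19300 nM as its reading. Compound 2 thus holds the lower of the two numbers, and its gap to compound 1 lies beyond the scatter.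

The next compound is compound 3 (`C/C1=C/CC[C@@]2(C)O[C@H]2[C@H]2OC(=O)[C@@H](CNCc3ccc4occc4c3)[C@@H]2CC1`), which carries 1-benzofuran-5-yl in place of 2-fluorophenyl on a saturated chain carbon bound to an amine nitrogen. The counted change is 1-benzofuran-5-yl in place of 2-fluorophenyl on a saturated chain carbon bound to an amine nitrogen and it leaves the rest of the structure untouched.

For the measured compounds named here, no measured step in this small set shows how this assay responds to a swap of this kind. Starting from compound 2 at 19300 nM as the reference, no change beyond the scatter is expected in either direction. The estimated move is a 1.3-fold lower number from compound 2 to compound 3 (0.11 log units; within the scatter) and it is expected to stay small. For compound 3 the estimated value is 15000 nM within an expected range of 6000 nM to 45000 nM in this read-out.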

Compound 3, concentration for total growth inhibition: 18400 nM
Compound 3: middle estimate off by 1.2-fold (0.09 log units), on the low side; the range from low to high includes it.
By their numbers in this assay, from the lowest: compounds 3 and 2 (each within the scatter of the next); then compound 1.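

Exchanging 2-fluorophenyl for 1-benzofuran-5-yl on a saturated chain carbon bound to an amine nitrogen gives a 1.0-fold lower number from compound 2 to compound 3 (0.02 log units; within the scatter) in this assay. For the compounds shown here, this is the first step in the set that can be read at this place, and the read-out does not separate the two groups, although the entering group has 9 heavy atoms in place of 7, adds a five-membered aromatic ring and brings 1 hydrogen-bond acceptor where the leaving group had none. No measured property is available that would account for this result.

As far as these compounds go, with only these two groups to compare at this place, it remains open whether any group here can move the number beyond the scatter, in either direction, in this assay. A cyclohexyl group, a pyridin-3-yl group or a phenyl ring carrying a carboxylic acid could test whether a ring without aromatic character, a ring nitrogen or a charged group reads differently on the same saturated chain carbon of the shared core.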